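Acyl cap of compound 3: isopropyl to tert-butyl

The source may hold more compounds than are shown below. What is called first, only, known or untested is meant among the compounds shown, and "the series" means these compounds.

Three compounds of the series share one core and differ only in the group on the carbonyl carbon. Compound 1 `CC(C)(C)OC(=O)N1CCC[C@@H]1C(=O)N1CCC(NS(=O)(=O)c2cc(S(=O)(=O)c3ccccc3)ccc2C(F)(F)F)CC1` gives 210 nM in a functional assay on U2OS cells for antagonist activity at proto-oncogene Wnt-3 (Homo sapiens), read by a luciferase reporter, with a stated time of 18 h; on this read-out lower numbers stand for an effect already at smaller amounts and higher numbers for an effect only at larger amounts of compound. Compound 2 `O=C1CC[C@@H](C(=O)N2CCC(NS(=O)(=O)c3cc(S(=O)(=O)c4ccccc4)ccc3C(F)(F)F)CC2)N1` gives 240 nM in this assay. Compound 3 `CC(C)C(=O)N1CCC[C@H]1C(=O)N1CCC(NS(=O)(=O)c2cc(S(=O)(=O)c3ccccc3)ccc2C(F)(F)F)CC1` gives 90 nM in this assay, the lowest of the three numbers: the steps of a 2.3-fold lower number from compound 1 to compound 3 (0.37 log units; beyond the scatter) and a 2.7-fold lower number from compound 2 to compound 3 (0.43 log units; beyond the scatter) both lie beyond the scatter, whereas a 1.1-fold higher number from compound 1 to compound 2 (0.06 log units; within the scatter) does not.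

Compound 4 `CC(C)(C)C(=O)N1CCC[C@H]1C(=O)N1CCC(NS(=O)(=O)c2cc(S(=O)(=O)c3ccccc3)ccc2C(F)(F)F)CC1` differs from compound 3 by methyl in place of hydrogen on a saturated chain carbon bound to a carbonyl carbon and two saturated chain carbons. Going by the values given here, no measured step is of this kind; the steps into compound 3 replace the whole group on the ring nitrogen rather than a single hydrogen. Compound 1 also carries a tert-butyl, though on oxygen, and sits at 210 nM. The measured steps show that the cap matters only modestly, and the change here is a single methyl, so no step beyond the scatter is expected, perhaps a slight drift upward. Compound 4 is therefore expected at 120 nM, within 50 nM to 280 nM. The estimate corresponds to a 1.3-fold higher number from compound 3 to compound 4 (0.12 log units; within the scatter).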

Compound 4, half-maximal effective concentration: 270 nM
Compound 4: middle estimate off by 2.3-fold (0.35 log units), on the low side, within the range that was stated.
By their numbers in this assay, from the lowest: compound 3; then compounds 1, 2 and 4 (each within the scatter of the next).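

In this assay, a single methyl in place of hydrogen on the saturated chain carbon bound to a carbonyl carbon and two saturated chain carbons is enough for a step beyond the scatter (a 3.0-fold higher number from compound 3 to compound 4 (0.48 log units; beyond the scatter)), so this position responds to one added carbon and not only to replacement of the whole group on the ring nitrogen. The advantage of compound 3 does not survive the change, as a 1.3-fold higher number from compound 1 to compound 4 (0.11 log units; within the scatter) and a 1.1-fold higher number from compound 2 to compound 4 (0.05 log units; within the scatter) both lie within the scatter, leaving compound 3 alone at the low end of the four numbers. Nothing available explains this step.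

Whether isopropyl is a narrow optimum remains open, as the compounds shown give no reading for a smaller acetyl cap or a cyclopropylcarbonyl cap. Going by these compounds, how an amine or a carboxylic acid on the cap would read also remains open.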